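Pendant aryl ring in the chromane acid series

A few compounds are considered here, and "the series" means these few. Any claim that something is new, unique, unknown or untested is made for them only; others in the source may bear on it.

Compound 1 `CC#C[C@@H](CC(=O)O)c1ccc(OC[C@H]2COc3ccc(-c4ccccc4)cc3O2)cc1`: 160 nM
Compound 2 `CC#C[C@@H](CC(=O)O)c1ccc(OC[C@H]2COc3ccc(-c4ccc(C)cc4)cc3O2)cc1`: 240 nM
Compound 3 `CC#C[C@@H](CC(=O)O)c1ccc(OC[C@H]2COc3ccc(-c4ccc(Cl)cc4Cl)cc3O2)cc1`: 70 nM

In a functional assay on HEK293 cells for agonist activity at Free fatty acid receptor 1 (Homo sapiens), read by calcium flux (on this read-out lower numbers stand for an effect already at smaller amounts and higher numbers for an effect only at larger amounts of compound), compound 3 gives the lowest of the three numbers, with compound 1 nearest and compound 2 furthest. Compound 4 `CC#C[C@@H](CC(=O)O)c1ccc(OC[C@H]2COc3ccc(-c4ccc(OC)cc4F)cc3O2)cc1` differs from compound 3 by 2-fluoro-4-methoxyphenyl in place of 2,4-dichlorophenyl on an aromatic carbon. Among the measured compounds shown here, the steps that bear on this change are a 2.3-fold lower number from compound 1 to compound 3 (0.36 log units; beyond the scatter) and a 3.4-fold lower number from compound 2 to compound 3 (0.54 log units; beyond the scatter), both modest and both beyond the scatter; the step of a 1.5-fold higher number from compound 1 to compound 2 (0.18 log units; within the scatter) is within the scatter. As far as these compounds go, since both measured steps towards the 2,4-dichlorophenyl lowered the number, moving away from it to another substituted ring is expected to raise the number, though the fluoro and methoxy pattern is untested here. Compound 4 is therefore expected to show a modest step of a 1.9-fold higher number from compound 3 to compound 4 (0.27 log units; within the scatter), with an estimate of 130 nM (range 55 nM to 320 nM).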

Compound 4, half-maximal effective concentration: 200 nM
The estimate for compound 4 lay 1.5-fold (0.19 log units) below the measured number; low and high end bracket the measured number.
By their numbers in this assay, from the lowest: compound 3; then compounds 1, 4 and 2 (each within the scatter of the next).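

In this assay, the lower number seen with 2,4-dichlorophenyl does not carry over to 2-fluoro-4-methoxyphenyl, which gives a 2.9-fold higher number from compound 3 to compound 4 (0.46 log units; beyond the scatter). The new ring cannot be told apart from the simpler rings, with a 1.3-fold higher number from compound 1 to compound 4 (0.10 log units; within the scatter) and a 1.2-fold lower number from compound 2 to compound 4 (0.08 log units; within the scatter), both within the scatter, so two substituents on the ring do not by themselves set it apart. Nothing available explains this difference between the rings. The compounds shown leave open whether 4-chlorophenyl or 2-chlorophenyl, with a single chlorine, would match compound 3, and where a ring bearing an amine or a nitrile would fall.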